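A few compounds are considered here, and "the series" means these few. Any claim that something is new, unique, unknown or untested is made for them only; others in the source may bear on it.

The measured compounds so far:

Compound 1 `O=C(O)c1csc([C@H]2CC[C@@H]3[C@@H](COc4ccc(OC(F)(F)F)cc4)[C@H](O)C[C@@H]3O2)n1` gives 14 nM in a functional assay on CHO cells for agonist activity at prostaglandin E2 receptor EP2 subtype (Homo sapiens), read by HTRF and cAMP accumulation, with a stated time of 30 min; on this read-out lower numbers stand for an effect already at smaller amounts and higher numbers for an effect only at larger amounts of compound.
Compound 2 `Cc1ccc(OC[C@@H]2[C@H]3CC[C@H](c4nc(C(=O)O)cs4)O[C@H]3C[C@H]2O)cc1` gives 27 nM.
Compound 3 `Cc1cccc(OC[C@@H]2[C@H]3CC[C@H](c4nc(C(=O)O)cs4)O[C@H]3C[C@H]2O)c1` gives 3.6 nM.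

All three share one core and differ only in the aromatic ring that hangs from the oxygen on a saturated carbon. Between compound 2 and compound 3 the two have the same atoms joined differently: 3-methylphenyl in place of 4-methylphenyl on an oxygen on a saturated carbon. This gave a 7.5-fold lower number from compound 2 to compound 3 (0.88 log units; beyond the scatter). Between compound 2 and compound 1 the change is trifluoromethoxy in place of methyl on an aromatic carbon, and it gave a 1.9-fold lower number from compound 2 to compound 1 (0.29 log units; within the scatter). Compound 3 stands lowest of the three, with both other compounds beyond the usual scatter above it.

Compound 4 `O=C(O)c1csc([C@H]2CC[C@@H]3[C@@H](COc4cccc(OC(F)(F)F)c4)[C@H](O)C[C@@H]3O2)n1` has not been measured. It differs from compound 3 by trifluoromethoxy in place of methyl on an aromatic carbon. The same kind of change was made from compound 2 to compound 1, but not at the same place: there the new group sat para to a large group, whereas here it sits meta to a large group. Among the measured compounds shown here, only one earlier example of this change exists, so the expectation rests on that single step. Compound 4 is expected to show a step of a 1.4-fold lower number from compound 3 to compound 4 (0.16 log units; within the scatter) because the same kind of change gave a 1.9-fold lower number from compound 2 to compound 1 (0.29 log units; within the scatter). Compound 4 is therefore estimated at about 2.5 nM, most likely between 0.9 nM and 7 nM.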

Compound 4, half-maximal effective concentration: 0.9 nM
Estimate against measurement, compound 4: 2.8-fold (0.44 log units) above, within the range that was stated.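

In this assay, putting trifluoromethoxy in place of methyl on the aromatic ring gave a 4.0-fold lower number from compound 3 to compound 4 (0.60 log units; beyond the scatter), so the new step lies beyond the scatter on its own. Set beside the earlier example of this change, the new step shows no real difference in size, so within this small set the change carries over from one core to the other: the same change on two cores in this assay, a 1.9-fold lower number (0.29 log units; within the scatter) from compound 2 to compound 1 and a 4.0-fold lower number (0.60 log units; beyond the scatter) from compound 3 to compound 4, 2.1-fold (0.32 log units) apart, within the scatter of two such steps This rests on only two pairs, one of which lies within the scatter when taken alone, and the new group also sits in a different place on the ring in each pair, so the data neither separate an effect of place from an effect of the core nor show that the step would hold on any other core.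

The compounds shown carry only a methyl or a trifluoromethoxy group on this aromatic ring, which leaves open whether a chlorine atom, a nitrile or a longer chain such as propyl would fit the same picture. Also open, as far as these compounds go, is whether the step would keep its size if an amide stood in place of the carboxylic acid that all four compounds share.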